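The source may report more compounds than this note shows. Statements on the series, on what has been measured and on what is new or still open speak of the compounds shown alone.

In an ADME assay on Jejunum (Mus musculus, strain C57BL/6) for metabolic stability, read by HPLC, with a stated time of 12 h (a lower number here means that the compound disappears faster, a higher number that the compound lasts longer), compound 1 `O=C(O)[C@@H](CO)NC(=O)[C@H]1C[C@H](O)CN1` gives > 12 h, which is a limit and not a number. Compound 2 `O=C(O)[C@H](CO)NC(=O)[C@H]1C[C@@H](O)CN1` gives > 12 h, also a limit. Compound 1 therefore stands at the limit of > 12 h in this assay, at which 2 of the 3 values shown sit, and a step that the two limits leave unreadable from compound 1 to compound 2. Compound 3 `O=C(N[C@H](CO)C(=O)O)[C@@H]1C[C@@H](O)CN1` gives a measured 0.33 h. That is an at least 36-fold lower number from compound 1 to compound 3 (1.56 log units; beyond the scatter), and likewise an at least 36-fold lower number from compound 2 to compound 3 (1.56 log units; beyond the scatter).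

Compound 4 `O=C(O)[C@H](CO)NC(=O)[C@@H]1C[C@@H](O)CN1` has not yet been measured. It is the mirror image of compound 1: the two compounds have the same atoms and bonds and differ only in configuration as drawn: 3 of 3 stereo elements differ (all stereocentres are inverted: mirror images); a stereocentre at a saturated chain carbon is drawn R in compound 1 and S in compound 4; a stereocentre at a saturated ring carbon is drawn R in compound 1 and S in compound 4; a stereocentre at a saturated ring carbon is drawn S in compound 1 and R in compound 4. Both ring stereocentres change from compound 1 as they do in the large step to compound 3, an at least 36-fold lower number from compound 1 to compound 3 (1.56 log units; beyond the scatter). The chain stereocentre also changes from R to S, as it does in the step to compound 2, but that step gives no readable size. The ring change is therefore the better guide, and a large fall is expected, an at least 40-fold lower number from compound 1 to compound 4 (1.60 log units; beyond the scatter). For compound 4 the estimated half-life is 0.3 h, with an expected range from 0.08 h to 1.2 h.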

Compound 4, half-life: 0.35 h
Compound 4: the middle estimate sits 1.2-fold (0.07 log units) below what was measured, and the stated range covers the measured number.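

In this assay, within the data shown here, a single ring stereocentre now changes alone for the first time, going from R to S in an at least 34-fold lower number from compound 2 to compound 4 (1.53 log units; beyond the scatter). Among these compounds, the chain stereocentre also changes alone for the first time, and a 1.1-fold higher number from compound 3 to compound 4 (0.03 log units; within the scatter) shows that, with the ring carbons as drawn in these two compounds, this change from R to S has no effect beyond the scatter. Inverting all three stereocentres gives an at least 34-fold lower number from compound 1 to compound 4 (1.53 log units; beyond the scatter), so the two mirror images do not last alike.

Among the compounds shown here, the step from compound 1 to compound 2 cannot be read, both values being limits, and the other ring stereocentre has no single step of its own, so the effect of each of these changes alone stays open. Nor do these compounds tell whether an amine in place of the ring hydroxyl, or an ester in place of the carboxylic acid, would keep this dependence on configuration.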